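The source may report more compounds than this note shows. Statements on the series, on what has been measured and on what is new or still open speak of the compounds shown alone.

Measured so far:
compound 1 `O=C(CSc1nnnn1-c1cccc2ccccc12)N/N=C/c1ccco1` gives > 330000 nM in an ADME assay on MT4 cells (Homo sapiens) for cytotoxicity, read by MTT assay; a lower number here means that less compound is tolerated, a higher number that more compound is tolerated.
compound 2 `O=C(CSc1nnnn1-c1cccc2ccccc12)N/N=C/c1ccccc1F` gives >= 118000 nM in this assay.

The value of compound 1 is a limit of this assay and not a number. The value of compound 2 is likewise a limit and not a number. Because the limit of > 330000 nM in this assay, at which 1 of the 2 values shown sits, and the limit of >= 118000 nM in this assay, at which 1 of the 2 values shown sits, are both limits, the step that the two limits leave unreadable from compound 1 to compound 2 cannot be read in size or direction, and compound 2 therefore stands only at a limit, with no measured number to place it against.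

Compound 3 `COc1ccc(/C=N/NC(=O)CSc2nnnn2-c2cccc3ccccc23)cc1` has not yet been measured in this assay. It differs from compound 2 in one place: 4-methoxyphenyl in place of 2-fluorophenyl on a carbon with a double bond to nitrogen. Within the data shown here, the only measured step, from compound 1 to compound 2, bears on the same position but is unreadable, so the data give no readable guide to the size of the new step in this assay. A step no larger than the scatter is expected, since both measured compounds sit at limits. Compound 3 is therefore expected near 150000 nM, in a range from 50000 nM to 500000 nM. The step that the limit leaves unreadable from compound 2 to compound 3 is expected to stay within the scatter, with a good chance that this assay again reports only a limit.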

Compound 3, half-maximal cytotoxic concentration: > 298000 nM
Compound 3 gave a limit, no number; the forecaster's own chance of this, stated with the estimate: 70%; middle value at least 1.9-fold (0.29 log units) from the limit.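

In this assay, compound 3 gave only a limit and not a number, as did compound 1 and compound 2, and the steps linking compound 3 to compound 1 and compound 2 cannot be read in size or direction. The compounds shown leave open whether the group on the carbon with a double bond to nitrogen affects the concentration tolerated.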